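This account rests on a few compounds, and the source may have more. Where it says the series, first, only, none or still open, it means among the compounds named here.

Working notes on the series, all read in a functional assay on LOX IMVI cells (Homo sapiens) for inhibition, read by sulforhodamine B assay, with a stated time of 48 h; on this read-out lower numbers stand for stronger inhibition of growth and higher numbers for weaker inhibition of growth. Compound 1 (`COc1cc2nc(-c3ccc(C(F)(F)F)cc3)cc(OCCCN3CCCC3)c2cc1OC`) gives 275 nM, compound 2 (`COc1cc2nc(-c3ccc(Cl)cc3)cc(OCCCN3CCCC3)c2cc1OC`) gives 446 nM, and compound 3 (`COc1cc2nc(-c3ccc(C(F)(F)F)cc3)cc(OCCCN3CCC(O)CC3)c2cc1OC`) gives 447 nM. Compound 2 therefore stands within the scatter of both other compounds, and the three are not separated on these numbers.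

The next compound is compound 4 (`COc1cc2nc(-c3ccc(Cl)cc3)cc(OCCCN3CCCCC3)c2cc1OC`), with piperidin-1-yl in place of pyrrolidin-1-yl on a saturated chain carbon, three bonds along the chain from an oxygen on an aromatic ring. The closest evidence is the change at this same place, a 1.6-fold higher number from compound 1 to compound 3 (0.21 log units; within the scatter), although 4-hydroxypiperidin-1-yl is the group entering there. The change of chloro for trifluoromethyl, a 1.6-fold higher number from compound 1 to compound 2 (0.21 log units; within the scatter), lies elsewhere on the structure and bears on this step only indirectly. Going by the values given here, no measured pair isolates the plain piperidin-1-yl group, so no step beyond the scatter is expected in this assay.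

The expected step is a 1.1-fold lower number from compound 2 to compound 4 (0.03 log units; within the scatter).

Compound 4 is estimated at 420 nM, with an expected range of 200 nM to 880 nM.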

Compound 4, concentration for total growth inhibition: 435 nM
Estimate against measurement, compound 4: 1.0-fold (0.02 log units) below, within the range that was stated.
By their numbers in this assay, from the lowest: compounds 1, 4, 2 and 3 (each within the scatter of the next).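

Going by these compounds alone, with chloro held constant, this pair isolates the ring at the end of the chain, which the earlier compounds did not do, since the only earlier change at this place also brought in a hydroxyl group. In this assay the step is a 1.0-fold lower number from compound 2 to compound 4 (0.01 log units; within the scatter), so pyrrolidin-1-yl and piperidin-1-yl, on a saturated chain carbon three bonds along the chain from an oxygen on an aromatic ring, are not separated here by the difference in ring size. No measurement available bears on why these two numbers lie so close.

The compounds shown leave open whether piperidin-1-yl gives the same reading with trifluoromethyl on the aromatic carbon, and whether 4-hydroxypiperidin-1-yl does so with chloro. They also leave open how a morpholin-4-yl group at this place, or a shorter 2-(piperidin-1-yl)ethyl chain, would read.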